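Chloro for trifluoromethoxy at the cytotoxicity limit

This account rests on a few compounds, and the source may have more. Where it says the series, first, only, none or still open, it means among the compounds named here.

In an ADME assay on BJ cells (Homo sapiens) for cytotoxicity, read by luminescence, with a stated time of 72 h (on this read-out higher numbers stand for an effect only at larger amounts of compound and lower numbers for an effect already at smaller amounts), compound 1 `CCOC(=O)c1c(-c2cccc(Cl)c2)[nH]c2cc(OC)ccc2c1=O` gives > 21500 nM as a limit. Compound 2 `CCOC(=O)c1c(-c2cccc(Oc3ccccc3)c2)[nH]c2cc(OC)c(F)cc2c1=O` gives > 21500 nM as a limit. Compound 3 `CCOC(=O)c1c(-c2cccc(OC(F)(F)F)c2)[nH]c2cc(OC)c(F)cc2c1=O` gives > 21500 nM as a limit, so it has no readable number. Among the measured compounds shown here, the series so far offers only the limit of > 21500 nM in this assay, at which 3 of the 3 values shown sit, and no measured value.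

Compound 4 `CCOC(=O)c1c(-c2cccc(Cl)c2)[nH]c2cc(OC)c(F)cc2c1=O` carries chloro in place of trifluoromethoxy on an aromatic carbon and remains unmeasured. For the measured compounds named here, the one measured step that bears on this change is a step that the two limits leave unreadable from compound 2 to compound 3 and it gives no size. No step beyond the scatter is therefore expected in this assay and no direction can be assigned. The estimated step is a step that the limit leaves unreadable from compound 3 to compound 4 as a working expectation. Compound 4 is estimated at 25000 nM with an expected span from 15000 nM to 45000 nM as the working range. A further limit is the likeliest report.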

Compound 4, half-maximal effective concentration: > 21500 nM
Compound 4 was reported as a limit; the forecaster's own chance of this, stated with the estimate: 90%; the middle value lies beyond the limit too.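

Compound 4 adds no readable step, and its comparisons with compound 1, compound 2 and compound 3 all remain unreadable: the limit of > 21500 nM in this assay, at which 4 of the 4 values shown sit. In this assay the compounds shown leave open at what concentration any of them would affect these cells.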